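The source may report more compounds than this note shows. Statements on the series, on what has been measured and on what is new or still open speak of the compounds shown alone.

Compound 1 `COC[C@H]1CN(c2ccc(OCC(C)O)cc2)C(=O)O1` stands second highest of three compounds in a physicochemical assay for lipophilicity; on this read-out lower numbers stand for lower lipophilicity and higher numbers for higher lipophilicity; compound 1 gives 1.17. Compound 2 `COC[C@H]1CN(c2ccc(CCO)cc2)C(=O)O1` gives 1.13, a step of a number 0.04 log units lower from compound 1 to compound 2 (within the scatter). Compound 3 `COC[C@H]1CN(c2ccc(OCC[C@@H](C)OC)cc2)C(=O)O1` gives 2.7, a step of a number 1.53 log units higher from compound 1 to compound 3 (beyond the scatter), and the step of a number 1.57 log units higher from compound 2 to compound 3 (beyond the scatter) is of the same size. Compound 4 `C=C(C)CCOc1ccc(N2C[C@H](COC)OC2=O)cc1` differs from compound 1 by 2-methylprop-2-en-1-yl in place of 1-hydroxyethyl on a saturated chain carbon bound to an oxygen on an aromatic ring. The step from compound 1 to compound 3 also replaces the 1-hydroxyethyl group on the same saturated chain carbon, and it was large and upward. In compound 4 the group that leaves carries one hydrogen-bond donor and one acceptor, while the group that enters carries none, so a large rise is expected, a number 2.03 log units higher from compound 1 to compound 4 (beyond the scatter). Compound 4 is estimated at 3.2, with a range from 2.6 to 3.8.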

Compound 4, partition coefficient: 3.03
Compound 4: the middle estimate sits 0.17 log units above what was measured; low and high end bracket the measured number.
By their numbers in this assay, from the lowest: compounds 2 and 1 (each within the scatter of the next); then compound 3; then compound 4.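

Replacing 1-hydroxyethyl with the all-carbon 2-methylprop-2-en-1-yl on a saturated chain carbon bound to an oxygen on an aromatic ring gives, in this assay, a step of a number 1.86 log units higher from compound 1 to compound 4 (beyond the scatter), and the wider change gives a step of a number 1.90 log units higher from compound 2 to compound 4 (beyond the scatter). Compound 3 had shown a large rise with 1-methoxyethyl further along the chain, yet the step of a number 0.33 log units higher from compound 3 to compound 4 (beyond the scatter) shows that 1-methylethenyl there reaches modestly higher still. No measured evidence here explains these rises. Going by these compounds, whether an amine or a carboxylic acid on this chain would bring the number down, or a longer chain would raise it further, stays open.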